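From 2-chlorophenyl to 5-chloro-2-hydroxyphenyl at the assay limit

The compounds below may be only part of what the source reports. "The series", "measured", "known", "first", "only" and "open" are said of these compounds alone.

In a functional assay on HepG2 cells (Homo sapiens) for antiproliferative activity, read by MTT assay, with a stated time of 24 h (a lower number here means a stronger inhibitor, a higher number a weaker inhibitor), compound 2 (`COc1ccc(C(=O)/C=C/c2ccccc2Cl)c2c1C=CC(C)(C)O2`) gives > 10000 nM, which is a limit of the assay and not a number. Compound 1 (`COc1ccc(C(=O)/C=C/c2ccc(Cl)c(Cl)c2)c2c1C=CC(C)(C)O2`) also gives only a limit, > 10000 nM. Within the data shown here, the one measured step, 2-chlorophenyl in place of 3,4-dichlorophenyl, is a step that the two limits leave unreadable from compound 1 to compound 2, and (the limit of > 10000 nM in this assay, at which 2 of the 2 values shown sit). Among the measured compounds shown here, no measured step therefore offers a size to carry forward.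

Compound 3 (`COc1ccc(C(=O)/C=C/c2cc(Cl)ccc2O)c2c1C=CC(C)(C)O2`) differs from compound 2 in one place: 5-chloro-2-hydroxyphenyl in place of 2-chlorophenyl on a double-bonded chain carbon bound to a double-bonded chain carbon. It carries 5-chloro-2-hydroxyphenyl in place of 2-chlorophenyl on a double-bonded chain carbon bound to a double-bonded chain carbon. With both measured compounds at the limit, only a small gain in this assay, if any, is expected, and a further limit is quite possible. The expected change is a step that the limit leaves unreadable from compound 2 to compound 3. For compound 3 the estimated value is 12000 nM, with an expected range from 3000 nM to 30000 nM.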

Compound 3, half-maximal inhibitory concentration: 6640 nM
Beside the measured number, compound 3's estimate is 1.8-fold (0.26 log units) above it, and the stated range covers the measured number.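

Among these compounds, with 5-chloro-2-hydroxyphenyl on a double-bonded chain carbon bound to a double-bonded chain carbon, compound 3 gives the first value in this assay that is a number and not a limit, so a change at this position can bring a reading into range. The change gives an at least 1.5-fold lower number from compound 2 to compound 3 (0.17 log units; that floor lies within the scatter), and set against the 3,4-dichlorophenyl group it gives an at least 1.5-fold lower number from compound 1 to compound 3 (0.17 log units; that floor lies within the scatter). Both are floors and not sizes, and neither is shown to lie beyond the scatter, because each starts from a limit: the limit of > 10000 nM in this assay, at which 2 of the 3 values shown sit.

The compounds shown leave open whether the hydroxy group or the changed place of the chlorine accounts for the reading, since the two differ together in compound 3. They also leave open how an amine or a carboxylic acid in place of that hydroxy group would read in this assay.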